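Bromo for Methyl, Repeated on a Second Core

The source may hold more compounds than are shown below. What is called first, only, known or untested is meant among the compounds shown, and "the series" means these compounds.

Compound 1 `Cc1ccc(-c2csc(NC(=O)COc3ccccc3C(C)C)n2)cc1` and compound 2 `CC(C)c1ccccc1OCC(=O)Nc1nc(-c2ccc(Br)cc2)cs1` share one core and differ by bromo in place of methyl on an aromatic carbon. In a functional assay on A549 cells (Homo sapiens) for cytotoxicity, read by MTT assay, with a stated time of 48 h (a higher number here means a weaker inhibitor, a lower number a stronger inhibitor), compound 1 gives 44200 nM, and compound 2 gives 48200 nM; the step of a 1.1-fold higher number from compound 1 to compound 2 (0.04 log units; within the scatter). Compound 3 `Cc1ccc(OCC(=O)Nc2nc(-c3ccc(C)cc3)cs2)cc1` rests on another core, and the difference between the two cores is not broken down here. In this assay compound 3 gives 48300 nM, a number within the scatter of both compound 1 and compound 2. Compound 4 `Cc1ccc(OCC(=O)Nc2nc(-c3ccc(Br)cc3)cs2)cc1` has not been measured yet and differs from compound 3 by bromo in place of methyl on an aromatic carbon, the same change that leads from compound 1 to compound 2. The expected step is a 1.0-fold higher number from compound 3 to compound 4 (0.02 log units; within the scatter), because the step of a 1.1-fold higher number from compound 1 to compound 2 (0.04 log units; within the scatter) stayed within the scatter. Compound 4 is accordingly estimated at 50000 nM, with a range from 28000 nM to 90000 nM.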

Compound 4, half-maximal inhibitory concentration: 58800 nM
Compound 4: middle estimate off by 1.2-fold (0.07 log units), on the low side; measured number inside the range.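

Carried to the second core, bromo in place of methyl gives, in this assay, a 1.2-fold higher number from compound 3 to compound 4 (0.09 log units; within the scatter). The change reads alike on both cores: the same change on two cores in this assay, a 1.1-fold higher number (0.04 log units; within the scatter) from compound 1 to compound 2 and a 1.2-fold higher number (0.09 log units; within the scatter) from compound 3 to compound 4, 1.1-fold (0.05 log units) apart, within the scatter of two such steps. Within the data shown here, this shows only that the change stayed within the scatter in two pairs in one assay; it does not show that the same would hold on any further core, and since neither step rises beyond the scatter, it does not show how a change with a clear effect would carry over.

The compounds shown leave open whether an amine or a carboxylic acid on that aromatic carbon, in place of methyl or bromo, would move the number beyond the scatter. They also leave open whether that result would match on both cores.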